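Ethyl to trifluoromethyl on the aromatic ring

The source may report more compounds than this note shows. Statements on the series, on what has been measured and on what is new or still open speak of the compounds shown alone.

Compound 3 `CCc1ccccc1C1C(=O)N(C)c2cnc(Nc3ccc(S(N)(=O)=O)cc3)nc2N1C` stands lowest of the three numbers measured in an assay on Sf9 cells for inhibition of serine/threonine-protein kinase 4 (Homo sapiens), read by luminescence and ADP-Glo, with a stated time of 1 h, in the presence of a further agent that is not named here (on this read-out higher numbers stand for weaker inhibition and lower numbers for stronger inhibition), where compound 3 gives 51 nM. Compound 1 `CN1C(=O)C(c2ccccc2)N(C)c2nc(Nc3ccc(S(N)(=O)=O)cc3)ncc21` gives 383 nM and compound 2 `CN1C(=O)C(c2cccc(F)c2)N(C)c2nc(Nc3ccc(S(N)(=O)=O)cc3)ncc21` gives 134 nM. The steps of a 2.9-fold lower number from compound 1 to compound 2 (0.46 log units; beyond the scatter) and a 7.5-fold lower number from compound 1 to compound 3 (0.88 log units; beyond the scatter) show that a substituent on the six-membered aromatic ring of carbon only lowered the number in both cases, and a 2.6-fold lower number from compound 2 to compound 3 (0.42 log units; beyond the scatter) separates the two substituted compounds.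

Compound 4 `CN1C(=O)C(c2ccccc2C(F)(F)F)N(C)c2nc(Nc3ccc(S(N)(=O)=O)cc3)ncc21` carries trifluoromethyl in place of ethyl on an aromatic carbon. Going by the values given here, no measured pair tests trifluoromethyl at this place; the nearest guides are the gain on adding ethyl, a 7.5-fold lower number from compound 1 to compound 3 (0.88 log units; beyond the scatter), and the smaller gain on adding fluoro, a 2.9-fold lower number from compound 1 to compound 2 (0.46 log units; beyond the scatter). Both gains are modest, and the new group again sits on the same aromatic carbon, so the step expected here, a 1.6-fold higher number from compound 3 to compound 4 (0.20 log units; within the scatter), is small and may not exceed the scatter, with a slight lean toward a higher number. Compound 4 is therefore expected to give 80 nM, with a range of 25 nM to 250 nM.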

Compound 4, half-maximal inhibitory concentration: 56 nM
Compound 4: middle estimate off by 1.4-fold (0.15 log units), on the high side; low and high end bracket the measured number.
By their numbers in this assay, from the lowest: compounds 3 and 4 (each within the scatter of the next); then compound 2; then compound 1.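

In this assay, trifluoromethyl and ethyl on this aromatic carbon cannot be told apart (a 1.1-fold higher number from compound 3 to compound 4 (0.04 log units; within the scatter)). The gain from replacing hydrogen here is therefore not particular to ethyl, since it also appears with trifluoromethyl (a 6.8-fold lower number from compound 1 to compound 4 (0.84 log units; beyond the scatter)), and this place accepts a group with fluorine in place of an all-carbon one with no measurable cost. The 2-(trifluoromethyl)phenyl group also keeps the advantage over 3-fluorophenyl that 2-ethylphenyl showed (a 2.4-fold lower number from compound 2 to compound 4 (0.38 log units; beyond the scatter)).

Nothing shown explains why the two groups read alike. As far as these compounds go, whether an amine, a carboxylic acid or a longer chain on this aromatic carbon would hold the number at the level of these two groups remains open.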